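Naphthalen-2-yl in place of 2,5-dimethylphenyl: expected cytotoxicity

This account rests on a few compounds, and the source may have more. Where it says the series, first, only, none or still open, it means among the compounds named here.

Two compounds have been measured in an ADME assay on C8166 cells (Homo sapiens) for cytotoxicity, read by MTT assay; a higher number here means that more compound is tolerated, a lower number that less compound is tolerated:
compound 1, `Cc1cc(S(N)(=O)=O)ccc1NC(=O)COc1ccc(Cl)cc1C(O)c1ccccc1`, gives 33400 nM.
compound 2, `Cc1ccc(C)c(C(O)c2cc(Cl)ccc2OCC(=O)Nc2ccc(S(N)(=O)=O)cc2C)c1`, gives 35500 nM.

Compound 2 carries the higher of the two numbers, but only just: the step of a 1.1-fold higher number from compound 1 to compound 2 (0.03 log units; within the scatter) lies within the scatter of the measurement, so compound 1 and compound 2 cannot be told apart on this read-out. That step is the only one available, and it concerns exactly the position that changes next, a saturated chain carbon bound to an aromatic carbon and an oxygen on a saturated carbon, where one aromatic group was exchanged for another.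

Compound 3, `Cc1cc(S(N)(=O)=O)ccc1NC(=O)COc1ccc(Cl)cc1C(O)c1ccc2ccccc2c1`, has not been measured. Its difference from compound 2 is naphthalen-2-yl in place of 2,5-dimethylphenyl on a saturated chain carbon bound to an aromatic carbon and an oxygen on a saturated carbon. Going by the values given here, since the one comparable exchange at this place, from compound 1 to compound 2, moved the number by a 1.1-fold higher number from compound 1 to compound 2 (0.03 log units; within the scatter), another exchange of an aromatic group there is expected to stay within the scatter too, in either direction: a 1.0-fold lower number from compound 2 to compound 3 (0.01 log units; within the scatter). Compound 3 is therefore estimated at 35000 nM in this assay, with a likely range from 17000 nM to 70000 nM.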

Compound 3, half-maximal cytotoxic concentration: 15700 nM
Beside the measured number, compound 3's estimate is 2.2-fold (0.35 log units) above it; the measured number lies below the stated range.
By their numbers in this assay, from the lowest: compound 3; then compounds 1 and 2 (each within the scatter of the next).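

Unlike the earlier exchange at this saturated chain carbon, this one gives a readable change in this assay: naphthalen-2-yl in place of 2,5-dimethylphenyl gives a 2.3-fold lower number from compound 2 to compound 3 (0.35 log units; beyond the scatter), and naphthalen-2-yl in place of phenyl gives a 2.1-fold lower number from compound 1 to compound 3 (0.33 log units; beyond the scatter). Both steps are modest, but they agree, and a lower number means that less compound is tolerated, so this position is not indifferent to every aromatic group placed on it: phenyl and 2,5-dimethylphenyl cannot be told apart here, while the group with 2 six-membered aromatic rings stands apart from both. Nothing available explains this difference in cytotoxicity.

Going by these compounds alone, with only three compounds, it remains open whether the lower number goes with the second fused ring in general or with naphthalen-2-yl alone. A cyclohexyl or pyridinyl group on the same carbon, or a benzyl group with one more carbon before the ring, would show how far the change extends beyond these aromatic groups of carbon only.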